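This account rests on a few compounds, and the source may have more. Where it says the series, first, only, none or still open, it means among the compounds named here.

Compound 3 `COc1cc2c(Oc3ccc(NC(=O)c4nn(-c5ccccc5F)c(=O)c5ccccc45)cc3F)ccnc2cc1OCCCN1CCCCC1` stands lowest of the three numbers in a functional assay on HT-29 cells (Homo sapiens) for cytotoxicity, read by MTT assay, with a stated time of 72 h; a lower number here means a stronger inhibitor, a higher number a weaker inhibitor: compound 3 gives 630 nM, while compound 1 `COc1cc2c(Oc3ccc(NC(=O)c4nn(-c5ccc([N+](=O)[O-])cc5)c(=O)c5ccccc45)cc3F)ccnc2cc1OCCCN1CCCC1` gives 1760 nM and compound 2 `COc1cc2c(Oc3ccc(NC(=O)c4nn(-c5ccc([N+](=O)[O-])cc5)c(=O)c5ccccc45)cc3F)ccnc2cc1OCCCN1CCN(C)CC1` gives 2560 nM. For the measured compounds named here, the only step measured between close neighbours, a 1.5-fold higher number from compound 1 to compound 2 (0.16 log units; within the scatter), changes the amine at the chain end and does not touch the change now in question. Compound 4 `COc1cc2c(Oc3ccc(NC(=O)c4nn(-c5ccc([N+](=O)[O-])cc5)c(=O)c5ccccc45)cc3F)ccnc2cc1OCCCN1CCCCC1` differs from compound 3 by 4-nitrophenyl in place of 2-fluorophenyl on an aromatic nitrogen. Going by the values given here, no measured step isolates this swap; what the data show is that compounds 1 and 2, which both carry the 4-nitrophenyl group, sit well above compound 3 in this assay. On that basis a rise is expected, a 2.4-fold higher number from compound 3 to compound 4 (0.38 log units; beyond the scatter). Compound 4 is therefore estimated at 1500 nM, within 600 nM to 4000 nM.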

Compound 4, half-maximal inhibitory concentration: 2170 nM
The estimate for compound 4 lay 1.4-fold (0.16 log units) below the measured number; low and high end bracket the measured number.
By their numbers in this assay, from the lowest: compound 3; then compounds 1, 4 and 2 (each within the scatter of the next).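

In this assay, the swap to 4-nitrophenyl from 2-fluorophenyl on the aromatic nitrogen now stands alone as a measured step (a 3.4-fold higher number from compound 3 to compound 4 (0.54 log units; beyond the scatter)), with piperidin-1-yl held fixed at the chain end. Changing the amine with 4-nitrophenyl in place does not separate the compounds (a 1.2-fold lower number from compound 2 to compound 4 (0.07 log units; within the scatter); a 1.2-fold higher number from compound 1 to compound 4 (0.09 log units; within the scatter)), as both steps lie within the scatter. No measurement shown here bears on the reason for the step. Open, as far as these compounds go, is whether it holds with pyrrolidin-1-yl or 4-methylpiperazin-1-yl at the chain end, and where phenyl, 4-fluorophenyl or 2-nitrophenyl would stand at this nitrogen.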